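The source may hold more compounds than are shown below. What is called first, only, known or untested is meant among the compounds shown, and "the series" means these compounds.

Measured so far:
Compound 1 `COc1ccc(S(=O)(=O)Nc2cc(Br)cc(Br)c2)cc1N1CCNCC1` gives 0.501 nM in an assay on isolated protein for binding affinity to 5-hydroxytryptamine receptor 6 (Homo sapiens); on this read-out higher numbers stand for weaker inhibition and lower numbers for stronger inhibition.
Compound 2 `COc1ccc(S(=O)(=O)Nc2ccc(Cl)c(Cl)c2)cc1N1CCNCC1` gives 2.51 nM in this assay.

Compound 2 stands at the higher of the two numbers: the step of a 5.0-fold higher number from compound 1 to compound 2 (0.70 log units; beyond the scatter) is beyond the scatter and leaves compound 1 as the stronger binder of the pair.

Compound 3 `COc1ccc(S(=O)(=O)Nc2c(F)cc(Br)cc2F)cc1N1CCNCC1` carries 4-bromo-2,6-difluorophenyl in place of 3,4-dichlorophenyl on a sulfonamide nitrogen. Among the compounds with values here, the only measured step touching this position, a 5.0-fold higher number from compound 1 to compound 2 (0.70 log units; beyond the scatter), shows that exchanging one dihalogenated phenyl ring for another can shift the number by a modest amount, but neither measured compound carries fluorine or the substitution pattern of compound 3, so no step speaks directly to this change. The expectation for compound 3 in this assay is therefore a step of a 1.3-fold lower number from compound 2 to compound 3 (0.10 log units; within the scatter), which sits within the scatter. The estimate for compound 3 is 2 nM, expected to fall between 0.5 nM and 8 nM.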

Compound 3, inhibition constant: 158 nM
The estimate for compound 3 lay 79-fold (1.90 log units) below the measured number; the measured number lies above the stated range.
By their numbers in this assay, from the lowest: compound 1; then compound 2; then compound 3.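

In this assay, within the data shown here, this position on the sulfonamide nitrogen proves far less forgiving than the first pair of compounds suggested, since replacing 3,4-dichlorophenyl with 4-bromo-2,6-difluorophenyl gives a 63-fold higher number from compound 2 to compound 3 (1.80 log units; beyond the scatter) and so a much larger change than the modest 5.0-fold higher number from compound 1 to compound 2 (0.70 log units; beyond the scatter) among the earlier rings. Measured against the 3,5-dibromophenyl group, the same ring gives a 320-fold higher number from compound 1 to compound 3 (2.50 log units; beyond the scatter) and leaves compound 3 clearly the weakest binder of the three, even though the groups exchanged count the same single aromatic ring of carbon, no hydrogen-bond donors or acceptors and no net charge. Nothing available here accounts for this loss of binding.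

Compound 3 changes the kinds of halogen and their placement in a single step, so the compounds shown do not separate these two changes. Going by these compounds, how an unsubstituted phenyl, or a phenyl carrying only fluorine, a methoxy group or an amine, would fare at this position remains open.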